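The source may report more compounds than this note shows. Statements on the series, on what has been measured and on what is new or still open speak of the compounds shown alone.

Working notes on the series in a functional assay on DU-145 cells (Homo sapiens) for cytotoxicity, read by CCK-8 assay; a higher number here means a weaker inhibitor, a lower number a stronger inhibitor.

Of the compounds shown here, three carry numbers so far. Going by the values given here, compound 1 `Oc1ccc(-c2cc(-c3cccs3)cc(-c3cccc(O)c3)n2)cc1` gives 1890 nM and compound 2 `Oc1ccc(-c2cc(-c3ccco3)cc(-c3cccc(O)c3)n2)cc1` gives 2070 nM; the one measured single-point step, a 1.1-fold higher number from compound 1 to compound 2 (0.04 log units; within the scatter), lies within the scatter. Compound 3 `Oc1ccc(-c2cc(-c3ccoc3)cc(-c3ccccc3O)n2)cc1` gives 28000 nM, the highest of the three numbers: the nearest is compound 2 and the furthest compound 1, and both of those gaps lie beyond the scatter.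

Compound 4 `Oc1ccc(-c2cc(-c3ccoc3)cc(-c3cccc(O)c3)n2)cc1` is not yet measured. It differs from compound 3 in one place: 3-hydroxyphenyl in place of 2-hydroxyphenyl on an aromatic carbon. Among the compounds with values here, no measured pair isolates this exact change. Within the data shown here, compounds 2 and 3 differ in two places, the hydroxyphenyl change and furan-2-yl against furan-3-yl; the step from compound 1 to compound 2 showed that a swap of the five-membered ring stayed within the scatter, so the large gap between compound 2 and compound 3 is the only guide available, and it points to a sizeable drop in the number.

Compound 4 is therefore expected to come in near the numbers of compounds 1 and 2, with a 9.3-fold lower number from compound 3 to compound 4 (0.97 log units; beyond the scatter) as the expected step. The estimate for compound 4 is 3000 nM, with a range from 1200 nM to 9000 nM.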

Compound 4, half-maximal inhibitory concentration: 2700 nM
Compound 4: the middle estimate sits 1.1-fold (0.05 log units) above what was measured; the range from low to high includes it.
By their numbers in this assay, from the lowest: compounds 1, 2 and 4 (each within the scatter of the next); then compound 3.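

In this assay, a 10-fold lower number from compound 3 to compound 4 (1.02 log units; beyond the scatter) isolates the exchange of 2-hydroxyphenyl for 3-hydroxyphenyl on the aromatic carbon next to the ring nitrogen, with furan-3-yl held constant, and shows that this single change can account for a large step at this place. The five-membered ring adds little by comparison: a 1.3-fold higher number from compound 2 to compound 4 (0.12 log units; within the scatter) and a 1.4-fold higher number from compound 1 to compound 4 (0.15 log units; within the scatter) both lie within the scatter, so with 3-hydroxyphenyl in place, thiophen-2-yl, furan-2-yl and furan-3-yl cannot be told apart in this assay. No supporting data on the compounds bear on what lies behind the large step.

On these data alone, the hydroxyphenyl change rests on a single pair, so whether a step of this size also appears with thiophen-2-yl or furan-2-yl remains open. Also open, as far as these compounds go, is where an aminophenyl or methoxyphenyl group at this same place would fall relative to compound 3 and compound 4.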